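A few compounds are considered here, and "the series" means these few. Any claim that something is new, unique, unknown or untested is made for them only; others in the source may bear on it.

Working notes on the series. Compound 1 `O=C(Cc1cccnc1)c1cc2cc(-c3ccccc3)ccc2[nH]1` was tested in an in vitro assay on P815B cells for inhibition of Indoleamine 2,3-dioxygenase 1 (Mus musculus), tested at 20 uM (a lower number here means less inhibition, a higher number more inhibition at the concentration tested (going by the name of the read-out)), and came back as "not active" (no number reported), so no single number stands for it; compound 2 `OC(Cc1cccnc1)c1cc2ccccc2[nH]1` is the one further entry of this kind, giving "not active" (no number reported) in this assay. For the measured compounds named here, compound 3 `O=C(Cc1ccccn1)c1cc2ccccc2[nH]1` is the only member of the set with a number: in this assay compound 3 gives 10%. Going by the values given here, no two measured compounds differ in one place only, so no measured step is available to guide the next move.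

Compound 4 `O=C(Cc1cccnc1)c1cc2cc(O)ccc2[nH]1` is the open entry. It differs from compound 1 in one place: hydroxy in place of phenyl on an aromatic carbon. Compound 1 carries no number in this assay, so the change cannot be set against a measured difference on its own parent. Given that compound 1 and compound 2 give no number and compound 3 gives 10%, the expected step for compound 4 in this assay is none beyond the scatter, in either direction. Compound 4 is therefore expected to give 10% in this assay, with a range from 0% to 25%, and a fair chance that the assay again reports no number.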

Compound 4, a percentage reported as inhibition, at one concentration (the size of the read-out at that concentration, not a potency): "not active" (no number reported)
Compound 4: no number reported; no gap can be computed for the estimate.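

Compound 1 and compound 4 both come back without a number, so no step can be read for hydroxy in place of phenyl. No evidence on hand bears on this result. The compounds shown leave open whether any substituent at this place on the shared core gives measurable inhibition.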